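The compounds below may be only part of what the source reports. "The series", "measured", "known", "first", "only" and "open" are said of these compounds alone.

Compound 1 `O=C(CCc1ccc(C(F)(F)F)cc1)Nc1ccc2nc(N3CCC3)ccc2c1`: 56 nM
Compound 2 `O=C(CCc1ccc(C(F)(F)F)cc1)Nc1ccc2nc(N3CC4CC3CN4)ccc2c1`: 490 nM
Compound 3 `CC1CCCN1c1ccc2cc(NC(=O)CCc3ccc(C(F)(F)F)cc3)ccc2n1`: 270 nM

All three compounds share one core and differ only in the saturated ring carried on an aromatic carbon of that core. They were tested in a functional assay on HEK293 cells for activation of melanin-concentrating hormone receptor 1 (Rattus norvegicus), read by inositol phosphate accumulation; on this read-out higher numbers stand for an effect only at larger amounts of compound and lower numbers for an effect already at smaller amounts. Compound 1 gives the lowest number of the three; its nearest neighbour is compound 3, with a 4.8-fold higher number from compound 1 to compound 3 (0.68 log units; beyond the scatter), and the furthest is compound 2, with an 8.8-fold higher number from compound 1 to compound 2 (0.94 log units; beyond the scatter). Both steps are beyond the usual scatter and both go the same way: replacing azetidin-1-yl with a larger ring gives a higher number.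

Compound 4 `O=C(CCc1ccc(C(F)(F)F)cc1)Nc1ccc2nc(N3CCCCCC3)ccc2c1` has not yet been tested in this assay. It differs from compound 1 in a single place: azepan-1-yl in place of azetidin-1-yl on an aromatic carbon. Azepan-1-yl is again a larger ring than azetidin-1-yl, so the two measured steps from compound 1 are the ones that bear on this change, and both were modest rises. A modest rise of similar size is therefore expected for compound 4, namely a 5.4-fold higher number from compound 1 to compound 4 (0.73 log units; beyond the scatter). Compound 4 is estimated at 300 nM, with a range from 100 nM to 900 nM.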

Compound 4, half-maximal effective concentration: 1800 nM
For compound 4 the middle estimate is 6.0-fold (0.78 log units) below the measured one, outside the stated range (above it).
By their numbers in this assay, from the lowest: compound 1; then compounds 3 and 2 (each within the scatter of the next); then compound 4.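

Azepan-1-yl shows that ring choice at this position can matter far more than the earlier compounds suggested, with a 32-fold higher number from compound 1 to compound 4 (1.51 log units; beyond the scatter) as the only large step in the set. Compound 4 also stands clear of both other substituted compounds, with a 6.7-fold higher number from compound 3 to compound 4 (0.82 log units; beyond the scatter) and a 3.7-fold higher number from compound 2 to compound 4 (0.57 log units; beyond the scatter) on top of that; the last step links two groups of 7 heavy atoms, so the count of heavy atoms alone does not set the number here. No available evidence explains why the seven-membered ring gives this result.

The simple rings pyrrolidin-1-yl and piperidin-1-yl would show whether the number climbs steadily with ring size from azetidin-1-yl to azepan-1-yl or jumps at some point. Going by these compounds, whether an open-chain dimethylamino group on the same carbon would follow the rings also remains open.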